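Removing a methoxy group from the aryl ketone of a chalcone pyrazole

The source may report more compounds than this note shows. Statements on the series, on what has been measured and on what is new or still open speak of the compounds shown alone.

The series comprises two measured chalcone-type compounds built on a shared core bearing a trimethoxyphenyl group, compound 1 `COc1cc(-c2cc(/C=C/C(=O)c3ccc(Cl)c(Cl)c3)[nH]n2)cc(OC)c1OC` and compound 2 `COc1ccc(C(=O)/C=C/c2cc(-c3cc(OC)c(OC)c(OC)c3)n[nH]2)cc1OC`. In a functional assay on OVCAR-8 cells (Homo sapiens) for cytotoxicity, read by sulforhodamine B assay, with a stated time of 48 h, tested at 0.1 uM (a lower number here means a stronger effect, a higher number a weaker effect of the compound at the concentration tested), compound 1 gives 97%, and compound 2 gives 92%. Within the data shown here, the only measured step, a number 5 percentage points lower from compound 1 to compound 2 (within the scatter), places compound 2 lowest of the two numbers, with compound 1 as its nearest neighbour within the scatter, so the two compounds cannot be ordered on these numbers.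

Compound 3 `COc1ccc(C(=O)/C=C/c2cc(-c3cc(OC)c(OC)c(OC)c3)n[nH]2)cc1` has not yet been measured. It differs from compound 2 in one place: hydrogen in place of methoxy on an aromatic carbon. Among the measured compounds shown here, no measured step shows this change, and the one step seen, from a dichlorophenyl to a dimethoxyphenyl on the carbonyl carbon, stayed within the scatter. With both measured compounds showing a weak effect at the concentration tested, compound 3 is expected to stay close to compound 2, and the estimated step of a number 1 percentage points higher from compound 2 to compound 3 (within the scatter) is expected to lie within the scatter. The estimate for compound 3 in this assay is therefore 93%, with a range from 82% to 101%.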

Compound 3, a percentage reported as activity, at one concentration (the size of the read-out at that concentration, not a potency): 98%
Compound 3: middle estimate off by 5 percentage points, on the low side, and the stated range covers the measured number.
By their numbers in this assay, from the lowest: compounds 2, 1 and 3 (each within the scatter of the next).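

Among these compounds, the 3,4-dimethoxyphenyl to 4-methoxyphenyl change is the first look at this aromatic carbon, ortho to a methoxy group and meta to a large group. In this assay hydrogen in place of methoxy there gives a number 6 percentage points higher from compound 2 to compound 3 (within the scatter) and so, at this one concentration, the read-out does not depend measurably on the methoxy group at this position. The second new step, with 4-methoxyphenyl in place of 3,4-dichlorophenyl on the carbonyl carbon, gives a number 1 percentage points higher from compound 1 to compound 3 (within the scatter) and so the three aryl ketones cannot be told apart in this assay and no data here offer an explanation for that.

Since all three compounds sit close together with a weak effect at the concentration tested, this result cannot show whether the position matters under conditions where the compounds act more strongly. On these data alone, whether an amine, a carboxylic acid or a longer chain such as butoxy on this aromatic carbon would move the number beyond the scatter remains open, as does the effect of any change to the trimethoxyphenyl group on the shared core.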